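The compounds below may be only part of what the source reports. "The series", "measured", "known", "first", "only" and "open" are said of these compounds alone.

Measured so far in a functional assay on Hep 3B2 cells (Homo sapiens) for antiproliferative activity, read by MTT assay, with a stated time of 24 h, tested at 0.41 ug/mL; on this read-out higher numbers stand for a stronger effect at the one concentration tested and lower numbers for a weaker effect:

Compound 1 `CCc1ccc2nc(C(=O)Nc3c(F)cc(-c4cccc(F)c4)cc3F)c(C)c(O)c2c1` gives 16.2%.
Compound 2 `COc1ccc2nc(C(=O)Nc3ccc(-c4ccccc4)cc3)c(C)c(O)c2c1` gives 7.58%.
Compound 3 `CCc1ccc2nc(C(=O)Nc3c(F)cc(-c4cccc(F)c4)cc3F)c(C)c(C(=O)O)c2c1` gives 1.68%.

Compound 3 differs from compound 1 by one change, (carboxy in place of hydroxy on an aromatic carbon), and this gave a number 14.5 percentage points lower from compound 1 to compound 3 (beyond the scatter). Compound 4 `COc1ccc2nc(C(=O)Nc3ccc(-c4ccccc4)cc3)c(C)c(C(=O)O)c2c1` is not yet measured; it differs from compound 2 by carboxy in place of hydroxy on an aromatic carbon, the same change at the same place, on a different core. How the core of compound 2 differs from that of compound 1 is not broken down here. Compound 2 sits within the scatter of compound 1 and of compound 3, so no order among them can be read. A step of a number 5.6 percentage points lower from compound 2 to compound 4 (within the scatter) is expected from compound 2 to compound 4, smaller than the earlier one because compound 2 starts from 7.58% and the read-out has little room to fall. Compound 4 is therefore estimated at 2%, between -5% and 10%.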

Compound 4, a percentage reported as inhibition, at one concentration (the size of the read-out at that concentration, not a potency): 5.31%
For compound 4 the middle estimate is 3.3 percentage points below the measured one; measured number inside the range.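

In this assay, carboxy in place of hydroxy gives a number 2.3 percentage points lower from compound 2 to compound 4 (within the scatter), so on this core the change has no effect that can be told from the usual scatter. Set beside the earlier step, the result gives no sign that the change behaves differently on the two cores: the same change on two cores in this assay, a number 14.5 percentage points lower (beyond the scatter) from compound 1 to compound 3 and a number 2.3 percentage points lower (within the scatter) from compound 2 to compound 4, 12.3 percentage points apart, within the scatter of two such steps This does not show that the change acts equally on both cores, only that these two steps, each read at a single concentration, reveal no difference.

Still open, on these data alone, is how other groups on this aromatic carbon, such as an amine or a primary amide, would compare with hydroxy and carboxy. The compounds shown also do not separate the individual differences between the two cores.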